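The compounds below may be only part of what the source reports. "The series", "measured", "known", "first", "only" and "open" are said of these compounds alone.

Measured in a functional assay on HSC-2 cells (Homo sapiens) for cytotoxicity, with a stated time of 24 h; on this read-out higher numbers stand for lower toxicity in this test and lower numbers for higher toxicity in this test:

compound 1 `O=C1/C(=C/c2ccc(F)cc2)CCC/C1=C\c1cccc([N+](=O)[O-])c1` — 2200 nM
compound 2 `O=C1/C(=C/c2ccc(Cl)cc2)CCC/C1=C\c1cccc([N+](=O)[O-])c1` — 2200 nM
compound 3 `O=C1/C(=C/c2ccc(F)cc2)CCC/C1=C\c1ccc([N+](=O)[O-])cc1` — 19000 nM

Compound 4 `O=C1/C(=C/c2ccc(Cl)cc2)CCC/C1=C\c1ccc([N+](=O)[O-])cc1` has not yet been measured in this assay. Between compound 1 and compound 2 the change is chloro in place of fluoro on an aromatic carbon; its step is no change at the digits printed from compound 1 to compound 2 (within the scatter). Compound 3 is built from the same atoms as compound 1, joined differently; the difference between the two cores is not broken down here. In this assay compound 3 gives the highest of the three numbers, beyond the scatter from both compound 1 and compound 2. Between compound 3 and compound 4 the change is chloro in place of fluoro on an aromatic carbon, the same change at the same place as before. The expected step is no change at the digits printed from compound 3 to compound 4 (within the scatter), because no change at the digits printed from compound 1 to compound 2 (within the scatter). Compound 4 is therefore estimated at 19000 nM, with a likely range from 8000 nM to 45000 nM.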

Compound 4, half-maximal cytotoxic concentration: 1500 nM
Compound 4: middle estimate off by 13-fold (1.10 log units), on the high side; measured number outside the range, below it.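

In this assay, chloro in place of fluoro does not carry over unchanged between these two cores: the same change on two cores in this assay, no change at the digits printed (within the scatter) from compound 1 to compound 2 and a 13-fold lower number (1.10 log units; beyond the scatter) from compound 3 to compound 4, 13-fold (1.10 log units) apart, beyond the scatter of two such steps A single expected step for 4-fluorophenyl to 4-chlorophenyl therefore does not hold across this series, and the large step, a 13-fold lower number from compound 3 to compound 4 (1.10 log units; beyond the scatter), cannot be assumed on another core. These two pairs do not show why the cores differ, nor which result a further core would follow.

The compounds shown leave open whether bromo, methyl or methoxy at the same place would follow the flat step or the large one. They also leave open how an amine in place of the nitro group would behave on either core.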